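Urea series: clearance in human liver microsomes

The source may report more compounds than this note shows. Statements on the series, on what has been measured and on what is new or still open speak of the compounds shown alone.

Measured so far:
compound 1 `CN(C)C(=O)c1cc(Cl)c(NC(=O)N2CCN3C(=O)N([C@H]4C[C@@H]4c4ccccc4)C(=O)[C@@H]3C2)c(Cl)c1`: 49000 mL.min-1.g-1
compound 2 `O=C(Nc1cccnc1-c1ccccc1)N1CCN2C(=O)N([C@H]3C[C@@H]3c3ccccc3)C(=O)[C@@H]2C1`: 45000 mL.min-1.g-1

The two measured compounds share the same core and differ only in the aryl group attached to the urea. In an in vitro ADME assay on microsomes from liver (Homo sapiens) for metabolic stability (on this read-out lower numbers stand for slow clearance and higher numbers for fast clearance), compound 1 gives 49000 mL.min-1.g-1, the highest of the two numbers. Compound 2 gives 45000 mL.min-1.g-1 in this assay. The two values lie within the usual scatter of each other, so no order between compound 1 and compound 2 is claimed; both simply sit at very fast clearance.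

Compound 3 `O=C(Nc1c(Cl)cc(F)cc1Cl)N1CCN2C(=O)N([C@H]3C[C@@H]3c3ccccc3)C(=O)[C@@H]2C1` has not yet been measured in this assay. It differs from compound 1 by fluoro in place of dimethylcarbamoyl on an aromatic carbon. Among the compounds with values here, no step between measured compounds matches this change, so there is no directly comparable pair to lean on. Given that compound 1 and compound 2 both read at very fast clearance despite carrying quite different aryl groups, the expectation is that the step from compound 1 to compound 3 stays within the scatter, in either direction, which is what a 1.0-fold higher number from compound 1 to compound 3 (0.01 log units; within the scatter) reflects. Compound 3 is therefore estimated at 50000 mL.min-1.g-1, with a range from 22000 mL.min-1.g-1 to 110000 mL.min-1.g-1.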

Compound 3, intrinsic clearance in microsomes: 64000 mL.min-1.g-1
For compound 3 the middle estimate is 1.3-fold (0.11 log units) below the measured one; low and high end bracket the measured number.
By their numbers in this assay, from the lowest: compounds 2, 1 and 3 (each within the scatter of the next).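

In this assay, exchanging dimethylcarbamoyl for fluoro on the aromatic carbon meta to two chloro groups and para to a large group gives a 1.3-fold higher number from compound 1 to compound 3 (0.12 log units; within the scatter) and so does not separate the two groups. Within the data shown here, this is the first pair that differs in one place, and it shows that this position accepts either dimethylcarbamoyl, with its 5 heavy atoms and 1 hydrogen-bond acceptor, or fluoro, with 1 heavy atom and no acceptor, with no reading beyond the scatter and clearance still very fast. No supporting measurement is available to explain this result.

Still open, from the compounds shown here alone, is whether a different group at this same carbon, such as an amine, a carboxylic acid or a longer chain, would give a number beyond the scatter of these values, and whether the same exchange would read alike without the two chloro groups. The compounds shown also leave open whether any change away from the aryl group on the urea, in the shared core itself, would bring clearance out of this very fast range.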